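Swapping a pyridinyl for a fluorophenyl on an alkyne

The source may hold more compounds than are shown below. What is called first, only, known or untested is meant among the compounds shown, and "the series" means these compounds.

Of the compounds shown here, three built on a shared core have been tested in a functional assay on MDA-MB-231 cells (Homo sapiens) for antiproliferative activity, read by WST assay, with a stated time of 72 h; a higher number here means a weaker inhibitor of growth, a lower number a stronger inhibitor of growth. Compound 1 `C#Cc1ccccc1N/N=N/c1ccc(C(=N)N)cc1` gives 23200 nM, and compound 3 `C#Cc1ccc(N/N=N/c2ccc(C(=N)N)cc2)cc1` gives 30200 nM. Compound 2 `N=C(N)c1ccc(/N=N/Nc2cccc(C#Cc3ccccn3)c2)cc1` gives 14400 nM, the lowest of the three numbers; its gap to compound 1 lies within the scatter of repeated measurements, while its gap to compound 3 lies beyond it. Compound 4 `N=C(N)c1ccc(/N=N/Nc2cccc(C#Cc3ccc(F)cc3)c2)cc1` has not yet been measured. It differs from compound 2 in one place: 4-fluorophenyl in place of pyridin-2-yl on a triple-bonded carbon. Going by the values given here, no measured pair shows this same change, so its effect is not known from these data. The step of a 1.0-fold higher number from compound 2 to compound 4 (0.02 log units; within the scatter) is expected to be small, not beyond the scatter, in no firm direction. Compound 4 is estimated at 15000 nM, with a range from 6000 nM to 40000 nM.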

Compound 4, concentration for 50% growth inhibition: 5500 nM
Compound 4: middle estimate off by 2.7-fold (0.44 log units), on the high side, outside the stated range (below it).
By their numbers in this assay, from the lowest: compound 4; then compounds 2, 1 and 3 (each within the scatter of the next, the first and the last beyond it).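

In this assay, 4-fluorophenyl in place of pyridin-2-yl on the triple-bonded carbon gives a 2.6-fold lower number from compound 2 to compound 4 (0.42 log units; beyond the scatter) and so shows that the ring on this alkyne can shift growth inhibition beyond the scatter. Going by these compounds alone, no earlier pair could show this, as none differed in one place. Nothing shown here explains the shift.

From the compounds shown here alone, the swap removes the ring nitrogen and adds the fluorine together, so the share of each remains open. A plain phenyl on the same triple-bonded carbon would separate the two.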